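From Ethoxy to Propyl at the Low End

The source may hold more compounds than are shown below. What is called first, only, known or untested is meant among the compounds shown, and "the series" means these compounds.

In a toxicity assay on microsomes from liver (Homo sapiens) for metabolic stability, read by LC-MS, using NADPH, tested at 1 uM (a lower number here means slower removal, a higher number faster removal of the compound), compound 1 `CCOc1ncc(-c2nc(C(F)(F)F)sc2N2CCN(C(=O)Cn3ccc4cnccc43)[C@H](C)C2)cn1` gives 656 mL.min-1.g-1 and compound 2 `CCOc1ncc(-c2nc(C(F)(F)F)sc2N2CCN(C(=O)Cn3ncc4cccnc43)[C@H](C)C2)cn1` gives 41 mL.min-1.g-1 on the same shared core. Compound 3 `CCOc1ncc(-c2nc(C(F)(F)F)sc2N2CCN(C(=O)Cn3nc(C)nc3C)[C@H](C)C2)cn1` stands at < 10 mL.min-1.g-1 and that figure is a limit of the assay, not a number. The three measured steps are a 16-fold lower number from compound 1 to compound 2 (1.20 log units; beyond the scatter) and an at least 65-fold lower number from compound 1 to compound 3 (1.81 log units; beyond the scatter) and an at least 4.1-fold lower number from compound 2 to compound 3 (0.61 log units; beyond the scatter) and all of them lie beyond the scatter. Compound 3 therefore sits lowest of the three on the numbers shown.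

Compound 4 `CCCc1ncc(-c2nc(C(F)(F)F)sc2N2CCN(C(=O)Cn3nc(C)nc3C)[C@H](C)C2)cn1` keeps everything in compound 3 except one group, with propyl in place of ethoxy on an aromatic carbon and the change lying on an aromatic carbon of a six-membered aromatic ring with 2 nitrogen. Within the data shown here, none of the measured steps touches this group, since all three compounds carry ethoxy, so they bear on the new step only indirectly and give it no size. They do show that numbers in this series can move widely with a single change of group. Among the measured compounds shown here, a small move towards faster removal is therefore expected, starting from the limit that compound 3 holds at < 10 mL.min-1.g-1 in this assay with no measured step to size it. The estimated change is an at least 1.2-fold higher number from compound 3 to compound 4 (0.07 log units; that floor lies within the scatter) and it is expected to be modest at most. For compound 4 the expected value is 12 mL.min-1.g-1 with an estimated range from 5 mL.min-1.g-1 to 40 mL.min-1.g-1 in this assay as the likely spread.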

Compound 4, intrinsic clearance in microsomes: 80 mL.min-1.g-1
Estimate against measurement, compound 4: 6.7-fold (0.82 log units) below; measured number outside the range, above it.
By their numbers in this assay, from the lowest: compounds 2 and 4 (each within the scatter of the next); then compound 1. At a limit, below all of these: compound 3.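

Among these compounds, compound 3, compound 1 and compound 2 all carry ethoxy, so this is the first reading of the place on the six-membered aromatic ring with 2 nitrogen: in this assay, propyl in place of ethoxy gives an at least 8.0-fold higher number from compound 3 to compound 4 (0.90 log units; beyond the scatter), which shows that this group, and not only the group on the saturated chain carbon bound to the carbonyl carbon, can move the number beyond the scatter. Ethoxy and propyl have the same count of heavy atoms and neither holds a ring, so the step comes from a swap in which an oxygen and its hydrogen-bond acceptor leave and a carbon enters. The value of compound 3, < 10 mL.min-1.g-1, is a limit of the assay and not a number, so the step gives only a floor, because it rests on that limit: the limit of < 10 mL.min-1.g-1 in this assay, at which 1 of the 4 values shown sits.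

Propyl appears here only with the group of compound 3, so it stays open whether the same swap would move the number by a similar amount with the groups of compound 1 or compound 2. Also open, on these data alone, is how methoxy, a longer chain such as butyl, or an amine at this same place would read in this assay.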